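The source may report more compounds than this note shows. Statements on the series, on what has been measured and on what is new or still open speak of the compounds shown alone.

Three compounds have numbers in a physicochemical assay for acid dissociation. Compound 1 `C[C@@]1(c2cc(NC(=O)c3cnc(OCF)cn3)ccc2F)CCC(F)(F)C(N)=N1` gives 7.6. Compound 2 `NC1=N[C@@]2(c3cc(NC(=O)c4cnc(OCF)cn4)ccc3F)COCC[C@H]2CC1(F)F` gives 6.6 and compound 3 `NC1=N[C@@]2(c3cc(NC(=O)c4cnc(OCF)cn4)ccc3F)CCOC[C@H]2CC1(F)F` gives 6.7, so these two lie within the scatter of each other, while both stand beyond the scatter under compound 1. Compound 4 `C[C@H]1C[C@H]2CC(F)(F)C(N)=N[C@@]2(c2cc(NC(=O)c3cnc(OCF)cn3)ccc2F)CO1` has not been measured. It departs from compound 2 by one change, methyl in place of hydrogen on a saturated ring carbon, next to the ring oxygen. Within the data shown here, no measured pair shows this change, so the expectation in this assay is a cautious one, of no shift beyond the scatter. The expected step of a number 0.10 log units higher from compound 2 to compound 4 (within the scatter) is small and upward. For compound 4 the estimate is 6.7, with a range from 6.3 to 7.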

Compound 4, acid dissociation constant: 6.6
For compound 4 the middle estimate is 0.10 log units above the measured one, within the range that was stated.
By their numbers in this assay, from the lowest: compounds 2, 4 and 3 (each within the scatter of the next); then compound 1.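

In this assay, methyl in place of hydrogen on a saturated ring carbon, next to the ring oxygen, gives no change at the digits printed from compound 2 to compound 4 (within the scatter). Among these compounds, this is the first measured pair with this change, and it shows that one added methyl at this position leaves the number where it stood. Nothing measured here offers an explanation for this result. As far as these compounds go, whether a longer chain such as ethyl, or an amine, on the same ring carbon would also leave the number in place remains open. A single methyl at one position also cannot tell what the same change would do on other ring carbons.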